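Hydroxy to carboxy exchange: three measured, one pending

This account rests on a few compounds, and the source may have more. Where it says the series, first, only, none or still open, it means among the compounds named here.

Compound 1 `CCOc1ccc2nc(C(=O)Nc3c(F)cc(-c4cccc(F)c4)cc3F)c(C)c(O)c2c1` carries a hydroxy group. In a functional assay on Hep 3B2 cells (Homo sapiens) for antiproliferative activity, read by MTT assay, with a stated time of 24 h, tested at 0.14 ug/mL (on this read-out lower numbers stand for a weaker effect and higher numbers for a stronger effect at the one concentration tested), compound 1 gives 0.01%. Compound 3 `CCOc1ccc2nc(C(=O)Nc3c(F)cc(-c4cccc(F)c4)cc3F)c(C)c(C(=O)O)c2c1` is its counterpart in which the change carboxy in place of hydroxy on an aromatic carbon has been made; in this assay compound 3 gives 2.06%. The step of a number 2.1 percentage points higher from compound 1 to compound 3 (within the scatter) is small, and nothing in it sets the two compounds apart.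

Compound 2 `COc1ccc2nc(C(=O)Nc3ccc(-c4ccccc4)cc3)c(C)c(O)c2c1` also carries a hydroxy group but differs from compound 1 in more than one place; the difference between the two cores is not broken down here. In this assay compound 2 gives 3.52%. The values of compound 2, compound 1 and compound 3 lie close together, and no order among the three measured compounds can be read from them.

Compound 4 `COc1ccc2nc(C(=O)Nc3ccc(-c4ccccc4)cc3)c(C)c(C(=O)O)c2c1` has not been measured. It stands to compound 2 as compound 3 stands to compound 1: the change carboxy in place of hydroxy on an aromatic carbon is described at a place worded exactly as for the earlier pair, so it is the same change made on the other core. Among the compounds with values here, the only guide is that earlier pair, whose step a number 2.1 percentage points higher from compound 1 to compound 3 (within the scatter) stayed within the scatter. The expected step of a number 2 percentage points higher from compound 2 to compound 4 (within the scatter) is set to match it, resting on the value of compound 2, 3.52%, and on the earlier step. Compound 4 is expected to give about 5.5% in this assay, with a likely range from -4% to 14%.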

Compound 4, a percentage reported as inhibition, at one concentration (the size of the read-out at that concentration, not a potency): 2.01%
For compound 4 the middle estimate is 3.5 percentage points above the measured one; the range from low to high includes it.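

Carboxy in place of hydroxy on the core of compound 2 gives, in this assay, a number 1.5 percentage points lower from compound 2 to compound 4 (within the scatter), so on this core the change does not set the two compounds apart. Set beside the same change on the core of compound 1, the new step does not differ from the earlier one: the same change on two cores in this assay, a number 2.1 percentage points higher (within the scatter) from compound 1 to compound 3 and a number 1.5 percentage points lower (within the scatter) from compound 2 to compound 4, 3.6 percentage points apart, within the scatter of two such steps This shows that, across these two pairs, the exchange gives no step that can be read on either core and no sign that the core alters its outcome, but it does not show that the exchange is without effect or that the two cores respond alike, since a single concentration gives no potency and a difference smaller than the scatter would go unseen here.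

The compounds shown leave open what other groups on the same aromatic carbon, such as an amine, a methoxy group or a nitrile, would give on either core. Within the data shown here, they also leave open how the exchange behaves on a core that gives a read-out well clear of the scatter, and no single-place pair here separates the several differences between the two cores.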